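Morpholin-4-yl in place of methylamino on compound 1

The source may hold more compounds than are shown below. What is called first, only, known or untested is meant among the compounds shown, and "the series" means these compounds.

compound 1 `CCN1CCc2c(sc(NC(=O)Nc3ccc(Cl)cc3)c2C(=O)NC)C1` gives > 25000 nM
compound 2 `NC(=O)c1c(NC(=O)Nc2ccc(Cl)cc2)sc2c1CCN(CCCNC(=O)CCc1cccnc1)C2` gives 470 nM

In a functional assay (strain AB) with Danio rerio as the target, read by microscopy, with a stated time of 1 h (on this read-out lower numbers stand for an effect already at smaller amounts and higher numbers for an effect only at larger amounts of compound), compound 1 gives > 25000 nM as a limit of the assay and not a number. Compound 1 thus stands at the limit of > 25000 nM in this assay, at which 1 of the 2 values shown sits, and has no number of its own. Compound 2 gives 470 nM as a measured number.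

Compound 3 `CCN1CCc2c(sc(NC(=O)Nc3ccc(Cl)cc3)c2C(=O)N2CCOCC2)C1` has not yet been measured. It keeps the core of compound 1 and carries morpholin-4-yl in place of methylamino on a carbonyl carbon so that methylcarbamoyl becomes (morpholin-4-yl)carbonyl. Among the compounds with values here, no measured pair shows what this change does in this assay and the size of the step has to be judged without one. The expectation is no step beyond the scatter, in either direction, and the assay may well report only a limit again. This expectation rests on compound 1, whose > 25000 nM is a limit. The expected size of the change is a step that the limit leaves unreadable from compound 1 to compound 3 and no more than that is estimated. For compound 3 the estimate is 30000 nM with an expected range of 8000 nM to 60000 nM on this read-out.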

Compound 3, half-maximal effective concentration: > 25000 nM
Compound 3: no number, only a limit; the forecaster's own chance of this, stated with the estimate: 75%; the middle value does not contradict the limit.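

In this assay compound 3 gives > 25000 nM, a limit of the assay and not a number. Compound 1 gives > 25000 nM, also a limit, so no step can be read between compound 1 and compound 3. The compounds shown leave open whether morpholin-4-yl in place of methylamino on a carbonyl carbon changes the effect at all.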